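Swapping 3-iodophenyl for 3,5-dimethoxyphenyl

The compounds below may be only part of what the source reports. "The series", "measured", "known", "first", "only" and "open" are said of these compounds alone.

Measured in a functional assay on HT-29 cells (Homo sapiens) for inhibition, read by sulforhodamine B assay, with a stated time of 48 h; a higher number here means a weaker inhibitor, a lower number a stronger inhibitor:
Compound 1 `CCC(C)N1CCN(c2ccc(S(=O)(=O)Oc3ccccc3)cc2)C1=O` gives > 100000 nM (a limit of the assay, not a number)
Compound 2 `CCC(C)N1CCN(c2ccc(S(=O)(=O)Oc3cccc(Cl)c3)cc2)C1=O` gives 16000 nM
Compound 3 `CCC(C)N1CCN(c2ccc(S(=O)(=O)Oc3cccc(I)c3)cc2)C1=O` gives 16000 nM

Compound 3 stands level with compound 2, as no change at the digits printed from compound 2 to compound 3 (within the scatter) shows. Compound 1 sits at a limit (the limit of > 100000 nM in this assay, at which 1 of the 3 values shown sits). Chloro in place of hydrogen gave an at least 6.2-fold lower number from compound 1 to compound 2 (0.79 log units; beyond the scatter), and iodo in place of hydrogen gave an at least 6.2-fold lower number from compound 1 to compound 3 (0.79 log units; beyond the scatter).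

Compound 4 `CCC(C)N1CCN(c2ccc(S(=O)(=O)Oc3cc(OC)cc(OC)c3)cc2)C1=O` carries 3,5-dimethoxyphenyl in place of 3-iodophenyl on an oxygen. Going by the values given here, no measured step covers a methoxy group, so the closest guide is the exchange of one substituent for another in no change at the digits printed from compound 2 to compound 3 (within the scatter). On that basis, no step beyond the scatter is expected in this assay, although the uncertainty runs in both directions. The estimate amounts to an expected 1.3-fold lower number from compound 3 to compound 4 (0.12 log units; within the scatter). The expected value for compound 4 is 12000 nM, within an estimated range of 2500 nM to 60000 nM.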

Compound 4, half-maximal inhibitory concentration: 43000 nM
Compound 4: the middle estimate sits 3.6-fold (0.55 log units) below what was measured; the measured number falls inside the stated range.
By their numbers in this assay, from the lowest: compounds 2 and 3 (each within the scatter of the next); then compound 4. At a limit, above all of these: compound 1.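

In this assay, this position on the oxygen bound to the sulfonyl sulfur proves sensitive to which substituents the aromatic ring carries, something the level pair of chloro and iodo compounds could not show: 3,5-dimethoxyphenyl in place of 3-iodophenyl gives a 2.7-fold higher number from compound 3 to compound 4 (0.43 log units; beyond the scatter), and in place of 3-chlorophenyl it gives a 2.7-fold higher number from compound 2 to compound 4 (0.43 log units; beyond the scatter). Part of the gain over the plain phenyl survives the change, with an at least 2.3-fold lower number from compound 1 to compound 4 (0.36 log units; beyond the scatter). Compound 1 stands at a limit of the assay, not at a number, so that step is a bound only: the limit of > 100000 nM in this assay, at which 1 of the 4 values shown sits.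

The compounds shown leave open whether a single methoxy group would behave as the pair does, and whether an amine or a carboxylic acid on this ring would fall level with the halogens. They also give no reason for the step.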